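Formyl in place of amino: an expected step

This account rests on a few compounds, and the source may have more. Where it says the series, first, only, none or still open, it means among the compounds named here.

Compound 1 `O=c1cc(I)n([C@@H]2O[C@H](CO)[C@@H](O)[C@H]2O)c(=O)[nH]1`: 27800 nM
Compound 2 `Nc1cc(=O)[nH]c(=O)n1[C@@H]1O[C@H](CO)[C@@H](O)[C@H]1O`: > 50000 nM

Both compounds were tested in a functional assay on cells (Homo sapiens) for antiproliferative activity, read by WST assay, with a stated time of 3 days; on this read-out lower numbers stand for stronger inhibition and higher numbers for weaker inhibition. Compound 2 gives > 50000 nM, which is a limit of the assay and not a number. So compound 2 has no exact position, and all that can be said is the limit of > 50000 nM in this assay, at which 1 of the 2 values shown sits.

Compound 3 `O=Cc1cc(=O)[nH]c(=O)n1[C@@H]1O[C@H](CO)[C@@H](O)[C@H]1O` differs from compound 2 in one place, with formyl in place of amino on an aromatic carbon.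

Going by the values given here, only one measured step bears on this same place: an at least 1.7-fold higher number from compound 1 to compound 2 (0.25 log units; that floor lies within the scatter). It shows no change beyond the scatter, and it involves amino and iodo, not formyl. Among the compounds with values here, compound 1 at 27800 nM is the only exact number available at this place, so it serves as the anchor for the expectation. A modest shift towards a lower number in this assay is therefore expected, with a wide margin.

Compound 3 is expected at about 32000 nM, with an estimated range of 10000 nM to 50000 nM. This estimate means an expected at least 1.5-fold lower number from compound 2 to compound 3 (0.19 log units; that floor lies within the scatter).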

Compound 3, half-maximal inhibitory concentration: > 50000 nM
Compound 3: no number, only a limit; the forecaster's own chance of this, stated with the estimate: 50%; middle value at least 1.5-fold (0.19 log units) away from the limit.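

In this assay, formyl at this position, like amino before it, leaves the read-out at a limit of the assay and not at a number, so among the compounds shown iodo remains the only group here with an exact value. Putting formyl in place of iodo gives an at least 1.7-fold higher number from compound 1 to compound 3 (0.25 log units; that floor lies within the scatter), so this step, like the one to amino, does not show that compound 1 truly stands apart. The step between amino and formyl cannot be read, because both compounds sit at the same limit and neither has an exact position: the limit of > 50000 nM in this assay, at which 2 of the 3 values shown sit.

As far as these compounds go, how far compound 2 and compound 3 each lie beyond that limit stays open, so amino and formyl cannot be ranked against each other. Also open, from the compounds shown here alone, is whether another group at this position, such as bromo, a carboxylic acid or a longer chain, would give an exact number in this assay, and how that number would stand against compound 1.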